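The source may hold more compounds than are shown below. What is called first, only, known or untested is meant among the compounds shown, and "the series" means these compounds.

In an ADME assay on HeLa cells (Homo sapiens) for cytotoxicity, read by MTT assay (on this read-out lower numbers stand for stronger inhibition and higher numbers for weaker inhibition), compound 3 `COC(=O)CNC(=O)CCC(=O)Oc1ccc(C[C@H]2C(=O)OC[C@@H]2Cc2ccc(OC)c(OC)c2)cc1OC` gives 179000 nM. Compound 2 `COc1ccc(C[C@H]2COC(=O)[C@@H]2Cc2ccc(OCc3cn(-c4ccc(Br)cc4)nn3)c(OC)c2)cc1OC` gives 128000 nM, and these two readings lie within the usual scatter of each other. Compound 1 `COc1ccc(C[C@H]2COC(=O)[C@@H]2Cc2ccc(OCc3cn(-c4ccc(F)cc4)nn3)c(OC)c2)cc1OC` reads >= 600000 nM, which is a limit and not a number.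

Compound 4 `COc1ccc(C[C@H]2COC(=O)[C@@H]2Cc2ccc(OC(=O)CCC(=O)N3CCCC3)c(OC)c2)cc1OC` has not yet been measured. Its structure departs from that of compound 3 by one swap: pyrrolidin-1-yl in place of ((methoxycarbonyl)methyl)amino on a carbonyl carbon. In plain terms, pyrrolidin-1-yl stands in place of ((methoxycarbonyl)methyl)amino on a carbonyl carbon.

Within the data shown here, only one measured step is available for comparison: an at least 4.6-fold lower number from compound 1 to compound 2 (0.67 log units; beyond the scatter). That step puts bromo in place of fluoro on an aromatic carbon, so it is a different change in a different place and gives no direct guide to this swap. It does show that a single substitution among these compounds can move the reading beyond the scatter, which argues for a wide range.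

Among the measured compounds shown here, with no measured step to suggest a direction, no shift beyond the scatter is expected, and the estimated step is a 1.2-fold lower number from compound 3 to compound 4 (0.08 log units; within the scatter). The estimated value for compound 4 is 150000 nM, with an expected range from 60000 nM to 450000 nM.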

Compound 4, half-maximal inhibitory concentration: 201000 nM
For compound 4 the middle estimate is 1.3-fold (0.13 log units) below the measured one; low and high end bracket the measured number.
By their numbers in this assay, from the lowest: compounds 2, 3 and 4 (each within the scatter of the next). At a limit, above all of these: compound 1.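

this assay responds to the swap of ((methoxycarbonyl)methyl)amino for pyrrolidin-1-yl on a carbonyl carbon with a 1.1-fold higher number from compound 3 to compound 4 (0.05 log units; within the scatter). Among these compounds, this is the first look at this position: an open chain with a hydrogen-bond donor and acceptors gives way to a five-membered non-aromatic ring with neither, and the reading does not move beyond the scatter, whereas the earlier halogen swap on an aromatic carbon did. The step joins two true numbers, since only compound 1 stands at a limit, which is not a number: the limit of >= 600000 nM in this assay, at which 1 of the 4 values shown sits.

On these data alone, it remains open whether a free carboxylic acid, a simple primary amine or a longer chain at this carbonyl carbon would move the reading. A single step also cannot show whether other rings, such as piperidine, would behave like pyrrolidin-1-yl.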